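The source may hold more compounds than are shown below. What is called first, only, known or untested is meant among the compounds shown, and "the series" means these compounds.

Compound 1 `COc1ccc(/C=C\c2cc(OC)c(OC)c(OC)c2)cc1OCc1ccc(CN2CCCC[C@H]2C(=O)O)cc1` and compound 2 `COc1ccc(/C=C\c2cc(OC)c(OC)c(OC)c2)cc1OCc1ccc(CN2CCCCC2C(=O)O)cc1` share the same atoms and bonds. In an ADME assay on NCM460 cells (Homo sapiens) for cytotoxicity, read by CCK-8 assay, with a stated time of 48 h (on this read-out higher numbers stand for weaker inhibition and lower numbers for stronger inhibition), compound 1 reaches only the assay limit, > 50000 nM. Compound 2 likewise reaches only the limit, > 50000 nM. The step that the two limits leave unreadable from compound 1 to compound 2 cannot be sized because the limit of > 50000 nM in this assay, at which 2 of the 2 values shown sit, caps both values, and the fact that one of compounds 1 and 2 is drawn with a defined configuration and the other without, at the place where they differ is all that separates the pair. Compound 3 `COc1ccc(/C=C\c2cc(OC)c(OC)c(OC)c2)cc1OCc1ccc(CNCCN(C)C)cc1` differs from compound 2 in one place: (2-(dimethylamino)ethyl)amino in place of 2-carboxypiperidin-1-yl on a saturated chain carbon bound to an aromatic carbon. No measured step bears on this change, so the numbers shown give no size or direction for it in this assay. Compound 3 is expected to give 30000 nM, within 6000 nM to 50000 nM. That expectation corresponds to an estimated step of an at least 1.6-fold lower number from compound 2 to compound 3 (0.22 log units; that floor lies within the scatter).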

Compound 3, half-maximal inhibitory concentration: 35000 nM
Compound 3: the middle estimate sits 1.2-fold (0.07 log units) below what was measured; the range from low to high includes it.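

In this assay, among these compounds, compound 3 gives 35000 nM, the only value shown that is not a limit, so (2-(dimethylamino)ethyl)amino on this saturated chain carbon yields a readable number. The change reads as an at least 1.4-fold lower number from compound 2 to compound 3 (0.15 log units; that floor lies within the scatter), and as an at least 1.4-fold lower number from compound 1 to compound 3 (0.15 log units; that floor lies within the scatter). As far as these compounds go, each is only a floor, so the full size of the change stays unknown, and the step between the two earlier compounds cannot be read.

From the compounds shown here alone, it remains open whether the carboxylic acid or the piperidine ring matters here. A piperidine without the carboxylic acid, or a longer chain ending in dimethylamino, could separate these.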